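The compounds below may be only part of what the source reports. "The series", "measured", "known", "first", "only" and "open" are said of these compounds alone.

Compound 2 `COc1cccc(-c2c(S(=O)(=O)c3ccc(C)c(C)c3)cnc3cc(F)ccc23)c1` is one of the two compounds whose behaviour in an ADME assay on microsomes from liver (Homo sapiens) for metabolic stability, tested at 2.5 uM (a higher number here means faster removal of the compound, a lower number slower removal), is known; the other is compound 1 `COc1cccc(-c2c(S(=O)(=O)c3ccc(OC)c(Cl)c3)cnc3cc(F)ccc23)c1`. In this assay compound 1 gives 1.71 mL/min, and compound 2 gives 8.78 mL/min, the higher of the two numbers. Going by the values given here, the single measured step, a 5.1-fold higher number from compound 1 to compound 2 (0.71 log units; beyond the scatter), concerns a replacement on a sulfonyl sulfur. Compound 3 `Cc1ccc(S(=O)(=O)c2cnc3cc(F)ccc3c2-c2cccc(F)c2)cc1C` has not yet been measured. It differs from compound 2 at another place: fluoro in place of methoxy on an aromatic carbon. Among the compounds with values here, no measured step bears on this change; the one step known touches a different part of the shared core, so there is no ground for expecting a shift beyond the scatter in either direction. Compound 3 is therefore expected to give about 7 mL/min in this assay, within a range from 3 mL/min to 16 mL/min. This corresponds to an expected step of a 1.3-fold lower number from compound 2 to compound 3 (0.10 log units; within the scatter).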

Compound 3, intrinsic clearance in a liver preparation (reported as CLH), per the amount of preparation that the assay uses: 3.71 mL/min
The estimate for compound 3 lay 1.9-fold (0.28 log units) above the measured number; measured number inside the range.
By their numbers in this assay, from the lowest: compound 1; then compound 3; then compound 2.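

The methoxy group on the aromatic carbon turns out to matter in this assay: the change to fluoro gives a 2.4-fold lower number from compound 2 to compound 3 (0.37 log units; beyond the scatter) and so moves the number beyond the scatter. Going by these compounds alone, until now, the only measured change was the one on the sulfonyl sulfur, and this second step shows that the number also responds at a separate place on the shared core, with the 3,4-dimethylphenyl group on the sulfonyl sulfur held constant. Nothing available explains the shift in either direction.

As far as these compounds go, this reading rests on a single pair, so it remains open whether fluoro in place of methoxy gives a similar step when the sulfonyl sulfur carries 3-chloro-4-methoxyphenyl instead. Also open, from the compounds shown here alone, is how other groups at this aromatic carbon, such as chloro, nitrile, an amine or a carboxylic acid, would behave.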